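This account rests on a few compounds, and the source may have more. Where it says the series, first, only, none or still open, it means among the compounds named here.

Of the compounds shown here, two built on one shared core have so far been tested in a functional assay on HCT-116 cells (Homo sapiens) for cytotoxicity, read by cell counting, with a stated time of 48 h (a higher number here means a weaker inhibitor, a lower number a stronger inhibitor), and both sit close together. Compound 1 `COc1ccccc1-n1cc(COc2cccc3cnc(Nc4cccc(Cl)c4)nc23)nn1` gives > 25000 nM as its reading, and this is a limit of the assay, not a number. Going by the values given here, compound 2 `COc1cccc(-n2cc(COc3cccc4cnc(Nc5cccc(Cl)c5)nc34)nn2)c1` gives 23000 nM as the only true number available, which makes it the one firm reference point. Compound 3 `Clc1cccc(Nc2ncc3cccc(OCc4cn(-c5cc(Cl)cc(Cl)c5)nn4)c3n2)c1` differs from it by 3,5-dichlorophenyl in place of 3-methoxyphenyl on an aromatic nitrogen and so carries 3,5-dichlorophenyl in place of 3-methoxyphenyl on an aromatic nitrogen. Among the compounds with values here, the only measured step at this place is an at least 1.0-fold lower number from compound 1 to compound 2 (0.03 log units; that floor lies within the scatter) whose floor lies within the scatter, and no measured compound carries chlorine on this ring. No step beyond the scatter is therefore expected in this assay in either direction, though compound 3 may also return only a limit. The expected change is a 1.3-fold lower number from compound 2 to compound 3 (0.11 log units; within the scatter) and it remains an estimate. For compound 3 the estimated value is 18000 nM with a range from 7000 nM to 30000 nM expected.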

Compound 3, half-maximal inhibitory concentration: 8000 nM
Compound 3: the middle estimate sits 2.3-fold (0.35 log units) above what was measured; low and high end bracket the measured number.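

In this assay, this position now shows a step beyond the scatter: 3,5-dichlorophenyl in place of 3-methoxyphenyl on the aromatic nitrogen gives a 2.9-fold lower number from compound 2 to compound 3 (0.46 log units; beyond the scatter). Going by these compounds alone, the only earlier step here had a floor within the scatter, so this is the first sign that the group at this position can shift the reading, and it does so with 8 heavy atoms and one six-membered aromatic ring in both the leaving and the entering group. Set against the 2-methoxyphenyl of compound 1, the same change gives an at least 3.1-fold lower number from compound 1 to compound 3 (0.49 log units; beyond the scatter), and that figure is only a floor because compound 1 gave a limit rather than a number: the limit of > 25000 nM in this assay, at which 1 of the 3 values shown sits.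

The compounds shown do not tell whether both chlorine atoms are needed for this step, or whether a 3-chlorophenyl, or a phenyl ring carrying an amine or a carboxylic acid, would lower the number further or raise it. As far as these compounds go, they also come from one cell line only, so whether the step holds in other cells remains open.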